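This account rests on a few compounds, and the source may have more. Where it says the series, first, only, none or still open, it means among the compounds named here.

Measured compounds:
- Compound 1, `COC(=O)[C@@]1(C)CCC=C2[C@@H]1CC[C@@H](C)[C@]2(C)Cc1c[nH]c2ccc(C(F)(F)F)cc12`: 14000 nM
- Compound 2, `COC(=O)[C@@]1(C)CCC=C2[C@@H]1CC[C@@H](C)[C@]2(C)Cc1c[nH]c2c(Br)cccc12`: 14000 nM
- Compound 3, `COC(=O)[C@@]1(C)CC[C@@H]2C3=C1CC[C@@H](C)[C@]3(C)C[C@@H]1c3ccccc3N[C@H]21`: 30000 nM

In a functional assay on SW1573 cells (Homo sapiens) for inhibition, read by sulforhodamine B assay, with a stated time of 48 h (a higher number here means a weaker inhibitor of growth, a lower number a stronger inhibitor of growth), compound 1 gives 14000 nM and compound 2 gives 14000 nM; these two values lie within the scatter of each other. Compound 3 stands at the highest of the three numbers with 30000 nM, and its gap to each of the other two, though modest, is beyond the scatter, so compound 3 is the weakest inhibitor of growth among the three.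

Compound 4, `COC(=O)[C@@]1(C)CC[C@@H]2C3=C1CC[C@@H](C)[C@]3(C)C[C@@H]1c3cc(C)ccc3N[C@H]21`, shares the core of compound 3 and differs from it only in methyl in place of hydrogen on an aromatic carbon. For the measured compounds named here, no step between measured compounds involves such a change, so the record gives no direct guide. A single methyl in place of hydrogen on an aromatic carbon is a small alteration, and in the absence of any shown step, a change within the scatter, in either direction, is the most reasonable expectation. Compound 4 is therefore estimated to give 25000 nM in this assay, with a range from 8000 nM to 80000 nM, the expected step being a 1.2-fold lower number from compound 3 to compound 4 (0.08 log units; within the scatter).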

Compound 4, concentration for 50% growth inhibition: 23000 nM
The estimate for compound 4 lay 1.1-fold (0.04 log units) above the measured number; measured number inside the range.
By their numbers in this assay, from the lowest: compounds 1, 2, 4 and 3 (each within the scatter of the next, the first and the last beyond it).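

In this assay, for the compounds shown here, methyl in place of hydrogen on an aromatic carbon gives a 1.3-fold lower number from compound 3 to compound 4 (0.12 log units; within the scatter), the first step that changes the structure in one place only. At this position, meta to a fused ring and para to a fused ring, the added methyl therefore leaves growth inhibition indistinguishable from that with hydrogen, so neither a gain nor a loss can be claimed for it. No measurement shown here speaks to the reason for this result.

The compounds shown leave open whether an amine, a carboxylic acid or a longer chain at this position would also stay within the scatter. They also leave open whether methyl on another carbon of the same aromatic ring would give a similar number.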